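From Ethyl to Propyl: Expected Cytotoxicity of Compound 3

This account rests on a few compounds, and the source may have more. Where it says the series, first, only, none or still open, it means among the compounds named here.

Compound 1 `CC(CCOc1ccc(-c2noc(C(C)(C)C)n2)cc1)CCN1CCN(c2ccnc(N)c2)C1=O` gives 55000 nM in an ADME assay on RD cells (Homo sapiens) for cytotoxicity, read by MTT assay, with a stated time of 24 h; on this read-out higher numbers stand for lower toxicity in this test and lower numbers for higher toxicity in this test. Compound 2 `CCc1nc(-c2ccc(OCCC(C)CCN3CCN(c4ccnc(N)c4)C3=O)cc2)no1` reaches only a limit of the assay, > 100000 nM, in this assay. For the measured compounds named here, the one measured step, an at least 1.8-fold higher number from compound 1 to compound 2 (0.25 log units; that floor lies within the scatter), ends at the limit of > 100000 nM in this assay, at which 1 of the 2 values shown sits. Compound 3 `CCCc1nc(-c2ccc(OCCC(C)CCN3CCN(c4ccnc(N)c4)C3=O)cc2)no1` differs from compound 2 by methyl in place of hydrogen on a saturated chain carbon, two bonds along the chain from an aromatic carbon. Going by the values given here, only that measured step bears on this change, and its floor lies within the scatter, so no shift beyond the scatter is expected. The expected step is therefore a number no higher from compound 2 to compound 3 (the limit leaves the size open). Compound 3 is estimated to give 100000 nM in this assay, between 50000 nM and 200000 nM, most likely reported again only as a limit.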

Compound 3, half-maximal cytotoxic concentration: > 100000 nM
Compound 3: no number, only a limit; the forecaster's own chance of this, stated with the estimate: 65%; the middle value lies on the limit itself.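

In this assay compound 3 also gives a limit and not a number, so the change from ethyl to propyl at this position cannot be read. Propyl in place of tert-butyl gives an at least 1.8-fold higher number from compound 1 to compound 3 (0.25 log units; that floor lies within the scatter), so this step, like the one to ethyl, shows no change beyond the scatter. The values now gather at one point: the limit of > 100000 nM in this assay, at which 2 of the 3 values shown sit.

The compounds shown leave open whether a longer chain such as butyl, or an amine, in place of propyl would give a readable number in this assay.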